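The source may hold more compounds than are shown below. What is called first, only, known or untested is meant among the compounds shown, and "the series" means these compounds.

Two members of the series have numbers in an ADME assay on Vero cells (Chlorocebus sabaeus) for cytotoxicity; on this read-out lower numbers stand for stronger inhibition and higher numbers for weaker inhibition. Compound 1 `Clc1ccc2cc(NCCNc3nc(NC4CCCCC4)nc(N4CCCCC4)n3)cnc2c1` gives 35300 nM in this assay. Compound 2 `Cc1ccccc1Nc1nc(NCCNc2cnc3cc(Cl)ccc3c2)nc(Nc2ccccc2C)n1` gives 29400 nM in this assay. Compound 2 stands at one end of the two numbers shown, but compound 1 lies within the scatter of it, so nothing separates the two on this read-out. Compound 3 `Cc1ccccc1Nc1nc(Nc2ccccc2C)nc(NC(C)CNc2cnc3cc(Cl)ccc3c2)n1` is not yet measured in this assay. It differs from compound 2 by methyl in place of hydrogen on a saturated chain carbon bound to a nitrogen on an aromatic ring and a saturated chain carbon. Among the measured compounds shown here, no step between measured compounds is available, so this change has no direct precedent here. A methyl added to the linking chain is expected to move this assay little, if at all. The step from compound 2 to compound 3 is estimated as a 1.0-fold higher number from compound 2 to compound 3 (0.01 log units; within the scatter), that is, nothing beyond the scatter. Compound 3 is therefore expected to give about 30000 nM in this assay, with a range from 12000 nM to 75000 nM.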

Compound 3, half-maximal inhibitory concentration: 26700 nM
For compound 3 the middle estimate is 1.1-fold (0.05 log units) above the measured one, within the range that was stated.
By their numbers in this assay, from the lowest: compounds 3, 2 and 1 (each within the scatter of the next).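

In this assay, among the compounds shown here, methyl in place of hydrogen on a saturated chain carbon bound to a nitrogen on an aromatic ring and a saturated chain carbon gives a 1.1-fold lower number from compound 2 to compound 3 (0.04 log units; within the scatter) as the only step between measured compounds. This chain carbon therefore carries a methyl without any shift beyond the scatter on this read-out, which the two earlier compounds, differing in more than one place, could not show. Nothing measured here speaks to the reason for this outcome.

Still open, from the compounds shown here alone, is whether a larger group on the same chain carbon, such as ethyl or hydroxymethyl, or a longer chain would also leave the read-out within the scatter. Going by these compounds, it is equally open whether the same methyl would behave this way on the chain of compound 1.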